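Butylamino for hexylsulfanyl in a series at its limit

This account rests on a few compounds, and the source may have more. Where it says the series, first, only, none or still open, it means among the compounds named here.

Compound 3 `CCCCCCSc1nc(N)nc2c1ncn2/C=C1/CC1(CO)CO` stands at > 20000 nM in an ADME assay on BCBL1 cells (Homo sapiens) for cytotoxicity, with a stated time of 7 days (a lower number here means that less compound is tolerated, a higher number that more compound is tolerated), and this is a limit, not a number. Compound 1 `CC(C)Nc1nc(N)nc2c1ncn2/C=C1/CC1(CO)CO` gives > 20000 nM as a limit too. Compound 2 `CCCCCCCCSc1nc(N)nc2c1ncn2/C=C1/CC1(CO)CO` likewise gives > 20000 nM as a limit. Compound 4 `CCCCNc1nc(N)nc2c1ncn2/C=C1/CC1(CO)CO` keeps the shared core and carries butylamino in place of hexylsulfanyl on an aromatic carbon as counted in butylamino in place of hexylsulfanyl on an aromatic carbon and nothing else changes.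

Among the measured compounds shown here, three measured steps bear on this change: a step that the two limits leave unreadable from compound 1 to compound 3 for hexylsulfanyl in place of isopropylamino, a step that the two limits leave unreadable from compound 1 to compound 2 for octylsulfanyl in place of isopropylamino and a step that the two limits leave unreadable from compound 2 to compound 3 between the two sulfanyl chains. None has a readable size, so they set no scale. Compound 1, compound 2 and compound 3 all fall under the limit of > 20000 nM in this assay, at which 3 of the 3 values shown sit, and so no step beyond the scatter is expected in this assay for butylamino. The expected step is a number no higher from compound 3 to compound 4 (the limit leaves the size open) and it remains an estimate. For compound 4 the estimate is 20000 nM with an expected range from 10000 nM to 40000 nM and a limit is the likelier outcome.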

Compound 4, half-maximal cytotoxic concentration: > 20000 nM
Compound 4: only a limit was reported (the forecaster's own chance of this, stated with the estimate: 85%); the middle value lies on the limit itself.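

No new step can be read between compound 4 and compound 1, compound 2 or compound 3 in this assay, since each value is only a limit: the limit of > 20000 nM in this assay, at which 4 of the 4 values shown sit.

Going by these compounds, whether butylamino, isopropylamino, hexylsulfanyl and octylsulfanyl differ at all in this assay stays open, as does the actual number for any of the four compounds.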